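Removing the methoxy from the core of compound 3

The compounds below may be only part of what the source reports. "The series", "measured", "known", "first", "only" and "open" are said of these compounds alone.

Compound 1, `CCOC(=O)c1nn(-c2ccc(OCC)cc2)cc1O`, in an assay on isolated protein for inhibition of patatin-like phospholipase domain-containing protein 2 (Mus musculus) (a lower number here means a stronger inhibitor, a higher number a weaker inhibitor), gives 120000 nM.
Compound 2, `CCOc1ccc(-n2cc(O)c(C(=O)OC)n2)cc1`, in this assay gives 130000 nM.
Compound 3, `CCOC(=O)c1nn(-c2ccc(OCC)cc2)cc1OC`, in this assay gives 90000 nM.

Compound 3 holds the lowest of the three numbers, but its nearest neighbour is compound 1 and the step of a 1.3-fold lower number from compound 1 to compound 3 (0.12 log units; within the scatter) lies within the scatter, as does the gap to compound 2, so no order among the three can be read. Compound 4, `CCOC(=O)c1ccn(-c2ccc(OCC)cc2)n1`, differs from compound 3 by hydrogen in place of methoxy on an aromatic carbon. Neither measured step tests this change directly: the step of a 1.1-fold higher number from compound 1 to compound 2 (0.03 log units; within the scatter) concerns the ester and the step of a 1.3-fold lower number from compound 1 to compound 3 (0.12 log units; within the scatter) only caps the oxygen that is now removed, and both stayed within the scatter. The shared core has therefore so far tolerated small changes at this position without a shift beyond the scatter, and the expectation for compound 4 is a step of about a 1.2-fold higher number from compound 3 to compound 4 (0.09 log units; within the scatter), a change that may well remain within the scatter. Compound 4 is thus estimated at 110000 nM, within a range from 40000 nM to 300000 nM.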

Compound 4, half-maximal inhibitory concentration: 40000 nM
Compound 4: middle estimate off by 2.8-fold (0.44 log units), on the high side, within the range that was stated.
By their numbers in this assay, from the lowest: compound 4; then compounds 3, 1 and 2 (each within the scatter of the next).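

Among these compounds, at the aromatic carbon next to the ring atom that bears an ethoxycarbonyl group, the earlier compounds could not separate hydroxy from methoxy in this assay, but removing the oxygen altogether gives a step beyond the scatter (a 2.3-fold lower number from compound 3 to compound 4 (0.35 log units; beyond the scatter)). The comparison with the hydroxy compound points the same way (a 3.0-fold lower number from compound 1 to compound 4 (0.48 log units; beyond the scatter)), so hydrogen at this carbon gives a lower number than either oxygen-linked group, though both steps are modest. No supporting measurement accounts for this difference.

The compounds shown leave open whether a fluorine, a methyl or an amine at this carbon would track with hydrogen or with the two oxygen-linked groups. They also leave open whether exchanging the ethyl ester for a methyl ester, which stayed within the scatter with hydroxy present, would do the same with hydrogen there.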